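Dipropylamino to dimethylamino: expected change in cytotoxicity

This account rests on a few compounds, and the source may have more. Where it says the series, first, only, none or still open, it means among the compounds named here.

Measured so far in an ADME assay on NIH3T3 cells (Mus musculus) for cytotoxicity (on this read-out higher numbers stand for lower toxicity in this test and lower numbers for higher toxicity in this test), are two compounds:
Compound 1 `CN1CCN(CC#Cc2cc3ncnc(Nc4ccc(OCc5cccc(F)c5)c(Cl)c4)c3s2)CC1` gives 4.8 uM
Compound 2 `CCCN(CC#Cc1cc2ncnc(Nc3ccc(OCc4cccc(F)c4)c(Cl)c3)c2s1)CCC` gives > 50 uM

Compound 2 stands at > 50 uM as a limit of the assay, not a number. Unmeasured compound 3 `CN(C)CC#Cc1cc2ncnc(Nc3ccc(OCc4cccc(F)c4)c(Cl)c3)c2s1` puts dimethylamino in place of dipropylamino on a saturated chain carbon bound to a triple-bonded carbon, and the change counts as dimethylamino in place of dipropylamino on a saturated chain carbon bound to a triple-bonded carbon in full. For the measured compounds named here, the only measured step at this place is an at least 10-fold higher number from compound 1 to compound 2 (1.01 log units; beyond the scatter) and this large step involved a different group, 4-methylpiperazin-1-yl. Compound 1 at 4.8 uM shows that another group here can give a far lower number, so a step to a lower number is expected in this assay with its size uncertain. The expected step is an at least 3.3-fold lower number from compound 2 to compound 3 (0.52 log units; beyond the scatter) as a rough estimate. For compound 3 the estimated value is 15 uM within an expected range from 4 uM to 50 uM and no narrower.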

Compound 3, half-maximal toxic concentration: > 50 uM
Compound 3: no number, only a limit; the forecaster's own chance of this, stated with the estimate: 20%; middle value at least 3.3-fold (0.52 log units) from the limit.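

In this assay compound 3 gives > 50 uM, a limit of the assay and not a number. Dimethylamino in place of 4-methylpiperazin-1-yl gives an at least 10-fold higher number from compound 1 to compound 3 (1.01 log units; beyond the scatter), so the smaller open-chain amine, like dipropylamino, does not share the low number of compound 1. The step between the two open-chain amines cannot be read, because both values sit at the limit: the limit of > 50 uM in this assay, at which 2 of the 3 values shown sit.

On these data alone, it remains open whether a ring amine with no second nitrogen, such as piperidin-1-yl, would give a low number like compound 1 or a limit like compound 2 and compound 3.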